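The source may hold more compounds than are shown below. What is called first, only, known or untested is meant among the compounds shown, and "the series" means these compounds.

In an ADME assay on a cell-free system (plasma, Rattus norvegicus) for metabolic stability, read by LC-MS, with a stated time of 60 min, tested at 100 uM (on this read-out lower numbers stand for a less stable compound and higher numbers for a more stable compound), compound 1 `Cc1cc(C(=O)O)ccc1OCCCCOc1ccc(C(=O)CC(C)C)c(O)c1C` gives 100%, compound 2 `Cc1c(OCCCCOc2ccc(C(=O)O)cc2)ccc(C(=O)CC(C)C)c1O` gives 95%, and compound 3 `Cc1ccc(C(=O)O)cc1OCCCCOc1ccc(C(=O)CC(C)C)c(O)c1C` gives 96%, so all three keep nearly all of the parent after the stated time. Compound 1 and compound 2 differ by hydrogen in place of methyl on an aromatic carbon, and that step reads a number 5 percentage points lower from compound 1 to compound 2 (within the scatter). The cores of compound 1 and compound 3 differ by 5-carboxy-2-methylphenyl in place of 4-carboxy-2-methylphenyl on an oxygen on a saturated carbon, with a step of a number 4 percentage points lower from compound 1 to compound 3 (within the scatter); between compound 2 and compound 3 the step is a number 1 percentage points higher from compound 2 to compound 3 (within the scatter).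

Compound 4 `Cc1c(OCCCCOc2cccc(C(=O)O)c2)ccc(C(=O)CC(C)C)c1O` has not yet been measured. It differs from compound 3 by hydrogen in place of methyl on an aromatic carbon. Among the measured compounds shown here, this is the same kind of change as the one from compound 1 to compound 2, but not the same: in compound 1 the leaving methyl sits meta to a carboxy group, whereas in compound 3 it sits para to a carboxy group. Because the earlier step of a number 5 percentage points lower from compound 1 to compound 2 (within the scatter) stayed within the scatter while every measured value sits near full recovery, the expected step in this assay is a number 2 percentage points lower from compound 3 to compound 4 (within the scatter). The estimated value for compound 4 is 94%, likely lying between 85% and 100%.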

Compound 4, percent of the compound remaining: 100%
Beside the measured number, compound 4's estimate is 6 percentage points below it; measured number inside the range.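

In this assay, hydrogen in place of methyl on an aromatic carbon reads a number 4 percentage points higher from compound 3 to compound 4 (within the scatter), and the other two new steps also stay inside the scatter: 3-carboxyphenyl in place of 4-carboxyphenyl gives a number 5 percentage points higher from compound 2 to compound 4 (within the scatter), and 3-carboxyphenyl in place of 4-carboxy-2-methylphenyl gives no change at the digits printed from compound 1 to compound 4 (within the scatter). Set beside the earlier step, the methyl change shows no difference that can be read between the two cores: the same change on two cores in this assay, a number 5 percentage points lower (within the scatter) from compound 1 to compound 2 and a number 4 percentage points higher (within the scatter) from compound 3 to compound 4, 9 percentage points apart, within the scatter of two such steps On these two cores, then, the change can be carried over as a step too small to read, and the opposite signs of the two steps carry no meaning; this does not show that the change would stay this small on a core that keeps less of its parent compound, as all four compounds here stay near full recovery.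

Still open, from the compounds shown here alone, is how the same change would read with an amide in place of the carboxy group. Going by these compounds, a longer linking chain or fluorine in place of the methyl is equally open.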